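Alkoxy variation on the benzylamide of the sulfonamide series

The compounds below may be only part of what the source reports. "The series", "measured", "known", "first", "only" and "open" are said of these compounds alone.

Two compounds of the series carry numbers in an assay on CHO cells for antagonist activity at transient receptor potential cation channel subfamily V member 1 (Homo sapiens), read by FLIPR; on this read-out lower numbers stand for stronger inhibition and higher numbers for weaker inhibition. Compound 1 `CC(C(=O)NCc1ccc(C(F)(F)F)cc1N1CCN(c2ccccc2)CC1)c1ccc(NS(C)(=O)=O)c(F)c1` gives 2 nM. Going by the values given here, compound 2 `CC(C)COc1cc(C(F)(F)F)ccc1CNC(=O)C(C)c1ccc(NS(C)(=O)=O)c(F)c1` gives 0.8 nM, the lowest of the two numbers; the only measured step, a 2.5-fold lower number from compound 1 to compound 2 (0.40 log units; beyond the scatter), replaces 4-phenylpiperazin-1-yl by isobutoxy on an aromatic carbon and lies beyond the scatter.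

Compound 3 `CC(C(=O)NCc1ccc(C(F)(F)F)cc1OC1CCCC1)c1ccc(NS(C)(=O)=O)c(F)c1` differs from compound 2 by cyclopentyl in place of isobutyl on an oxygen on an aromatic ring. Among the compounds with values here, the one measured step concerns a different exchange at the same oxygen-bearing position of the ring, an aryl-piperazine against an alkoxy group, and so it speaks only indirectly to the present change; no measured pair compares two alkyl ethers with each other. The exchange keeps the ether oxygen and adds one carbon atom while closing the alkyl into a ring, with no donors or acceptors gained or lost. The expectation is therefore a step within the scatter, with no direction claimed, as a 1.3-fold higher number from compound 2 to compound 3 (0.10 log units; within the scatter). For compound 3 the estimated value in this assay is 1 nM, with a range from 0.3 nM to 3 nM.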

Compound 3, inhibition constant: 0.6 nM
The estimate for compound 3 lay 1.7-fold (0.22 log units) above the measured number, within the range that was stated.
By their numbers in this assay, from the lowest: compounds 3 and 2 (each within the scatter of the next); then compound 1.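

Going by these compounds alone, exchanging isobutyl for cyclopentyl on an oxygen on an aromatic ring gives in this assay a 1.3-fold lower number from compound 2 to compound 3 (0.12 log units; within the scatter) as the first direct comparison of two alkyl ethers at this place, so an open chain and a five-membered non-aromatic ring of carbon only cannot be told apart on this read-out. Measured against the 4-phenylpiperazin-1-yl group, cyclopentyloxy gives a 3.3-fold lower number from compound 1 to compound 3 (0.52 log units; beyond the scatter) and so joins isobutoxy, for which the step is a 2.5-fold lower number from compound 1 to compound 2 (0.40 log units; beyond the scatter), on the same side of compound 1 and beyond the scatter in both cases. No independent measurement accompanies these numbers to account for the two ethers reading alike or for their separation from compound 1.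

The compounds shown span only one pair of alkyl ethers, so it remains open whether the read-out stays level with a smaller methoxy group, a longer chain such as n-hexyloxy or a larger cyclohexyloxy ring. As far as these compounds go, it is equally open whether a phenoxy group, a free hydroxyl or a simple amine at this place would fall with compound 2 and compound 3 or with compound 1.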